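A few compounds are considered here, and "the series" means these few. Any claim that something is new, unique, unknown or untested is made for them only; others in the source may bear on it.

Measured compounds in this series:

compound 1 `COc1ccc(-c2cc(O)c3c(C)cc(C)nc3n2)cc1` — 42700 nM
compound 2 `COc1ccccc1-c1cc(O)c2cccnc2n1` — 23400 nM
compound 3 `COc1ccc(-c2cc(O)c3ccc(C)nc3n2)cc1` — 89100 nM

All three numbers come from a functional assay on SF-295 cells (Homo sapiens); on this read-out lower numbers stand for stronger inhibition of growth and higher numbers for weaker inhibition of growth. Compound 3 and compound 1 share a core and differ in one place: methyl in place of hydrogen on an aromatic carbon. That change gives a 2.1-fold lower number from compound 3 to compound 1 (0.32 log units; beyond the scatter), a step that lies beyond the scatter.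

Compound 2 carries a different core; how it differs from compound 3 is not broken down here, and the two values are only compared as they stand. Compound 2 and compound 1 lie within the scatter of each other, so no order is drawn between them; compound 2 and compound 3 lie beyond it.

Compound 4 `COc1ccccc1-c1cc(O)c2cc(C)cnc2n1` has not been measured. It differs from compound 2 in one place: methyl in place of hydrogen on an aromatic carbon. Among the measured compounds shown here, this is the same kind of change as the one from compound 3 to compound 1, but the surroundings are not the same. In compound 1 the methyl sits ortho to a fused ring, meta to a fused ring, meta to a methyl group (1 heavy atom) and opposite the ring nitrogen; in compound 4 it sits two atoms from the ring nitrogen, meta to a fused ring and para to a fused ring, on a core that has no second methyl.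

For the measured compounds named here, with only one earlier example of this kind of change, the expectation for compound 4 rests on compound 3 and compound 1, whose step was a 2.1-fold lower number from compound 3 to compound 1 (0.32 log units; beyond the scatter). The place of the change in compound 4 is not the same as in compound 1. The step from compound 2 to compound 4 is expected to be a 1.6-fold lower number from compound 2 to compound 4 (0.19 log units; within the scatter), kept smaller than that earlier step. Compound 4 is therefore estimated at 15000 nM, with a likely range from 6000 nM to 40000 nM.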

Compound 4, concentration for 50% growth inhibition: 30900 nM
The estimate for compound 4 lay 2.1-fold (0.31 log units) below the measured number, and the stated range covers the measured number.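

In this assay, methyl in place of hydrogen on an aromatic carbon, here two atoms from the ring nitrogen, gives a 1.3-fold higher number from compound 2 to compound 4 (0.12 log units; within the scatter), so no order is drawn between these two compounds. The change therefore does not carry over from one core to the other at the same size, and the gap between the two steps is itself beyond the scatter: the same change on two cores in this assay, a 2.1-fold lower number (0.32 log units; beyond the scatter) from compound 3 to compound 1 and a 1.3-fold higher number (0.12 log units; within the scatter) from compound 2 to compound 4, 2.8-fold (0.44 log units) apart, beyond the scatter of two such steps. Among the compounds shown here, with only two pairs, this does not show whether the gap goes with the place of the methyl or with the rest of each core, as the two pairs differ in both, and it gives no general rule for the series.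

The compounds shown leave open how a methyl at another place on the core of compound 2 would read, which would separate place from core. They also leave open whether a different group at the place used in compound 4, such as an amine, a carboxylic acid or a longer chain, would give a step beyond the scatter on this core.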